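The compounds below may be only part of what the source reports. "The series", "measured", "known", "first", "only" and "open" are said of these compounds alone.

In an ADME assay on BJ cells (Homo sapiens) for cytotoxicity, read by luminescence, with a stated time of 72 h (a lower number here means that less compound is needed, a higher number that more compound is needed for the effect), compound 2 `CCOC(=O)c1c(-c2cccc(-c3ccccc3)c2)[nH]c2cc(OC)ccc2c1=O` gives only a limit of > 21500 nM. Compound 1 `C=Cc1cccc(-c2[nH]c3cc(OC)ccc3c(=O)c2C(=O)OCC)c1` gives a limit of > 21500 nM in this assay. Compound 3 `CCOC(=O)c1c(-c2cccc(S(C)(=O)=O)c2)[nH]c2cc(OC)ccc2c1=O` likewise gives a limit of > 21500 nM. All three values sit at the limit of > 21500 nM in this assay, at which 3 of the 3 values shown sit, so compound 2 stands at the same limit as its two neighbours and cannot be set above or below either of them. Compound 4 `CCOC(=O)c1c(-c2cccc(N(C)C)c2)[nH]c2cc(OC)ccc2c1=O` differs from compound 2 by dimethylamino in place of phenyl on an aromatic carbon. Among the compounds with values here, the measured steps that bear on this change are a step that the two limits leave unreadable from compound 1 to compound 2, a step that the two limits leave unreadable from compound 1 to compound 3 and a step that the two limits leave unreadable from compound 2 to compound 3; each has a size that cannot be read, and none of them involves a dimethylamino group, so the change itself has no measured precedent here. With every measured compound resting at the limit, the step that the limit leaves unreadable from compound 2 to compound 4 is expected to be none beyond the scatter, and compound 4 is expected to stay at the limit in this assay as well. Compound 4 is therefore estimated at 30000 nM, with a range from 10000 nM to 100000 nM.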

Compound 4, half-maximal effective concentration: > 21500 nM
Compound 4 gave a limit, no number (the forecaster's own chance of this, stated with the estimate: 85%); the middle value lies beyond the limit too.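

Compound 4 gives only a limit of > 21500 nM in this assay and no number. Its steps from compound 1, compound 2 and compound 3 therefore cannot be read. The compounds shown leave open how these four rank against one another and whether any group at this place would give a readable number.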